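A Nitro for a Methyl on a Tolerated Aniline

This account rests on a few compounds, and the source may have more. Where it says the series, first, only, none or still open, it means among the compounds named here.

For the measured compounds named here, compound 1 `Cc1ccc(Nc2cc(Oc3c(C)cc(Br)cc3C)c([N+](=O)[O-])cc2[N+](=O)[O-])cc1` is the only member of this set with a numerical reading in an ADME assay on H9 cells (Homo sapiens) for cytotoxicity, read by XTT assay, with a stated time of 6 days; a higher number here means that more compound is tolerated, a lower number that less compound is tolerated: in it compound 1 gives 53000 nM. Compound 2 `Cc1cc(C#N)cc(C)c1Oc1ccc([N+](=O)[O-])c(Nc2ccc(C#N)cc2)c1` reaches only a limit in this assay, namely > 65100 nM. Compound 3 `Cc1cc(C)c(Oc2cc(Nc3ccc(C#N)cc3)c([N+](=O)[O-])cc2[N+](=O)[O-])c(C)c1` likewise stops at a limit in this assay, namely > 59800 nM. No pair among these three differs in a single place, so no measured step is known. Compound 4 `Cc1cc(Br)cc(C)c1Oc1cc(Nc2ccc([N+](=O)[O-])cc2)c([N+](=O)[O-])cc1[N+](=O)[O-]` has not yet been measured; it differs from compound 1 by nitro in place of methyl on an aromatic carbon. Going by the values given here, with no measured step for this kind of change, the account expects the step of a 1.1-fold lower number from compound 1 to compound 4 (0.03 log units; within the scatter) to stay within the usual scatter. For compound 4 in this assay the estimate is 50000 nM, within the range 20000 nM to 100000 nM.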

Compound 4, half-maximal cytotoxic concentration: > 49700 nM
Compound 4: no number, only a limit; the forecaster's own chance of this, stated with the estimate: 30%; the middle value does not contradict the limit.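

In this assay compound 4 stops at a limit, > 49700 nM, and the step to it from compound 1 cannot be read. The compounds shown leave open whether nitro in place of methyl changes the tolerated concentration at all.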